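A few compounds are considered here, and "the series" means these few. Any claim that something is new, unique, unknown or untested is made for them only; others in the source may bear on it.

Measured compounds:
Compound 1 `CCC(COc1cccc(C(F)(F)F)c1)OC(=O)NCc1ccccc1`: in an assay for inhibition of zeta-carotene desaturase, chloroplastic/chromoplastic (Capsicum annuum), using a Dixon plot, with a stated time of 8 h (on this read-out higher numbers stand for weaker inhibition and lower numbers for stronger inhibition), compound 1 gives > 100000 nM, a limit of the assay, not a number.
Compound 2 `CCC(COc1cccc(F)c1)OC(=O)NCc1ccccc1`: in this assay compound 2 gives > 100000 nM, likewise a limit.
Compound 3 `CCC(COc1cccc(C#N)c1)OC(=O)NCc1ccccc1`: in this assay compound 3 gives > 100000 nM, likewise a limit.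

Compound 1 thus stands only at a limit in this assay, as do its two companions, all three sitting at the limit of > 100000 nM in this assay, at which 3 of the 3 values shown sit. The steps among them, a step that the two limits leave unreadable from compound 1 to compound 2, a step that the two limits leave unreadable from compound 1 to compound 3 and a step that the two limits leave unreadable from compound 2 to compound 3, are unreadable, both ends resting on the limit. Compound 4 `CCC(COc1cccc(C(F)(F)F)c1)OC(=O)Nc1ccccc1` differs from compound 1 by phenyl in place of benzyl on an amide-type nitrogen. Among the compounds with values here, no measured step touches the amide-type nitrogen; all three vary the aryl ether substituent, and none yields a size. The step that the limit leaves unreadable from compound 1 to compound 4 is therefore expected without guidance from the data. Compound 4 is estimated at 150000 nM with a range of 30000 nM to 500000 nM, most probably again reported only as a limit.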

Compound 4, half-maximal inhibitory concentration: > 100000 nM
Compound 4 was reported as a limit; the forecaster's own chance of this, stated with the estimate: 85%; the middle value is on the limit's open side.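

Compound 1 and compound 4 both rest on a limit in this assay, so no new step can be read between them: the limit of > 100000 nM in this assay, at which 4 of the 4 values shown sit.

The compounds shown leave open how phenyl and benzyl on the amide-type nitrogen compare, and whether any change to the shared core gives a readable value.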